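Fluoro to methoxy in a poorly soluble amide series

The source may hold more compounds than are shown below. What is called first, only, known or untested is meant among the compounds shown, and "the series" means these compounds.

Of the compounds shown here, three sharing one core have been measured in a physicochemical assay for solubility; on this read-out lower numbers stand for lower solubility and higher numbers for higher solubility. Compound 1 has the structure `O=C(Nc1nc(-c2cccc(C(F)(F)F)c2F)cs1)c1ccc(N2CCC(C(=O)O)CC2)nc1`. In this assay compound 1 gives < 10 ug/mL, which is a limit of the assay rather than a number. Compound 2, with structure `N#Cc1cc(C(=O)Nc2nc(-c3cccc(C(F)(F)F)c3F)cs2)cnc1N1CCC(C(=O)O)CC1`, carries a cyano group where compound 1 carries a hydrogen. In this assay compound 2 gives < 10 ug/mL, again only a limit. Compound 3 has the structure `O=C(Nc1nc(-c2cccc(C(F)(F)F)c2F)cs1)c1cnc(N2CCC(C(=O)O)CC2)c(F)c1`. In this assay compound 3 gives < 10 ug/mL, also a limit. The steps a step that the two limits leave unreadable from compound 1 to compound 2, a step that the two limits leave unreadable from compound 1 to compound 3 and a step that the two limits leave unreadable from compound 2 to compound 3 cannot be sized because of the limit of < 10 ug/mL in this assay, at which 3 of the 3 values shown sit.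

Compound 4, not yet measured, has the structure `COc1cc(C(=O)Nc2nc(-c3cccc(C(F)(F)F)c3F)cs2)cnc1N1CCC(C(=O)O)CC1`. It differs from compound 3 by methoxy in place of fluoro on an aromatic carbon. No measured step covers this change, and the three shown give no readable size at all. The step that the limit leaves unreadable from compound 3 to compound 4 is therefore expected to stay small, with a fair chance that only a limit is reported again. Compound 4 is expected to give 8 ug/mL, between 2 ug/mL and 30 ug/mL.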

Compound 4, solubility: < 10 ug/mL
Compound 4 was reported as a limit (the forecaster's own chance of this, stated with the estimate: 60%); the middle value lies beyond the limit too.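

In this assay the steps to compound 4 from compound 1, compound 2 and compound 3 cannot be read, because all four compounds sit at one limit: the limit of < 10 ug/mL in this assay, at which 4 of the 4 values shown sit.

From the compounds shown here alone, the actual solubility of each compound remains open, as does whether hydrogen, cyano, fluoro or methoxy at this place makes any difference.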